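A few compounds are considered here, and "the series" means these few. Any claim that something is new, unique, unknown or untested is made for them only; others in the source may bear on it.

Measured so far:
compound 1 `Nc1ncnc2c1ncn2[C@@H]1O[C@H](CO)C[C@H]1OP(=O)(O)OC[C@H]1O[C@@H](n2cnc3c(N)ncnc32)C[C@@H]1O`: 6%
compound 2 `Nc1ncnc2c1ncn2[C@H]1C[C@H](OP(=O)(O)OC[C@H]2O[C@@H](n3cnc4c(N)ncnc43)C[C@@H]2O)[C@@H](CO)O1`: 30%

In a functional assay for inhibition of Nucleic Acid, read by thymidine incorporation, tested at 50 uM (a higher number here means a stronger effect of the compound at the concentration tested, a lower number a weaker effect), compound 2 gives 30% and stands highest of the two numbers; compound 1 gives 6%. The gap between compound 2 and compound 1 lies beyond the scatter. Compound 3 `Nc1ncnc2c1ncn2[C@H]1C[C@H](OP(=O)(O)OC[C@H]2O[C@@H](n3cnc4c(N)ncnc43)C[C@@H]2O)[C@@H](COP(=O)(O)O)O1` differs from compound 2 by a group of 4 heavy atoms (3 oxygen, 1 phosphorus; no ring) in place of a hydrogen atom, on an oxygen on a saturated carbon. Going by the values given here, no measured pair covers a change of this kind, so its effect in this assay is uncertain. The expected step of a number 3 percentage points higher from compound 2 to compound 3 (within the scatter) is small, with no direction claimed beyond the scatter. For compound 3 the estimate in this assay is 33%, with a range from 10% to 58%.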

Compound 3, a percentage reported as inhibition, at one concentration (the size of the read-out at that concentration, not a potency): 18%
Compound 3: the middle estimate sits 15 percentage points above what was measured; the measured number falls inside the stated range.
By their numbers in this assay, from the lowest: compound 1; then compound 3; then compound 2.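

In this assay, a group of 4 heavy atoms (3 oxygen, 1 phosphorus; no ring) in place of a hydrogen atom, on an oxygen on a saturated carbon, gives a number 12 percentage points lower from compound 2 to compound 3 (beyond the scatter). Going by these compounds alone, this is the first measured change at this oxygen, and its direction is downward in this single pair. No available evidence bears on the reason for this step. Still open, as far as these compounds go, is whether a carboxylic acid or a methyl ether at the same oxygen would give a similar step. One pair cannot show whether any replacement of this hydrogen lowers the number.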